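The compounds below may be only part of what the source reports. "The series", "measured", "known", "first", "only" and "open" are said of these compounds alone.

Working notes on the series.

Two compounds of this set have been run in a functional assay on PANC-1 cells (Homo sapiens) for inhibition, read by MTT assay, with a stated time of 24 h, tested at 10 uM; a lower number here means less inhibition, a higher number more inhibition at the concentration tested (going by the name of the read-out). Compound 1, `CC(C)=CCC1Cc2c(OCc3ccccc3)cc(=O)n(CCCO)c2CC1(C)C`, gives 11.1% in this assay. Compound 2, `CC(C)=CCC1Cc2c(OCCCNC(=O)c3ccc([N+](=O)[O-])cc3)cc(=O)n(CCCO)c2CC1(C)C`, gives 9.1% in this assay. The two numbers lie within the scatter of each other, so compound 1 stands at the top of the pair in number only, and no order between compound 1 and compound 2 can be drawn. Among the compounds with values here, both values sit at the low end of what the read-out can report, and the set so far gives no step between measured compounds that could be read as a trend.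

The next compound, compound 3, `COc1cccc(NC(=O)Oc2cc(=O)n(CCCO)c3c2CC(CC=C(C)C)C(C)(C)C3)c1`, differs from compound 1 in one place: (3-methoxyphenyl)carbamoyl in place of benzyl on an oxygen on an aromatic ring. Within the data shown here, no measured pair in the set carries a change of this kind, so the direction of the step has no precedent here. Given the flat pair of values for compound 1 and compound 2, the step is expected to be a number 0.9 percentage points higher from compound 1 to compound 3 (within the scatter), that is, none beyond the scatter. Compound 3 is expected to give about 12% in this assay, between 3% and 26%.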

Compound 3, a percentage reported as inhibition, at one concentration (the size of the read-out at that concentration, not a potency): 0%
The estimate for compound 3 lay 12 percentage points above the measured number; measured number outside the range, below it.
By their numbers in this assay, from the lowest: compounds 3, 2 and 1 (each within the scatter of the next, the first and the last beyond it).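

Within the data shown here, on an oxygen on an aromatic ring, the change from benzyl to (3-methoxyphenyl)carbamoyl gives the first step in the set beyond the scatter in this assay: a number 11.1 percentage points lower from compound 1 to compound 3 (beyond the scatter). This shows that the group at this position can alter the read-out, even though it starts from a low value, and that keeping one six-membered aromatic ring of carbon only in the leaving and entering groups does not preserve the number. The entering group also differs in its heavy atoms, its double bond outside aromatic rings and its hydrogen-bond donor and acceptors, but no available measurement bears on which of these differences matters.

This single pair leaves open whether the step follows from the carbamoyl unit or from the 3-methoxyphenyl group, a question that a plain phenylcarbamoyl or a 3-methoxybenzyl group at the same oxygen would address. It also leaves open whether any group at this position, such as a longer chain ending in an amine, can raise the number beyond that of compound 1 at the single concentration tested.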